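This account rests on a few compounds, and the source may have more. Where it says the series, first, only, none or still open, it means among the compounds named here.

Compound 3 `CCCC(=O)NCCC(=O)c1cc(OC)ccc1N` stands second highest of the three numbers in an assay for inhibition of Nitric oxide synthase, inducible (Homo sapiens), read by scintillation counting, with a stated time of 30 min, tested at 1 mM (a higher number here means more inhibition at the concentration tested (going by the name of the read-out), a lower number less inhibition), where compound 3 gives 7.35%. Compound 1 `COc1ccc(N)c(C(=O)CCNC(C)=O)c1` gives 30.7% and compound 2 `CCC(=O)NCCC(=O)c1cc(OC)ccc1N` gives 0.24%. Lengthening the acyl chain has cost activity: a number 30.5 percentage points lower from compound 1 to compound 2 (beyond the scatter) and a number 23.4 percentage points lower from compound 1 to compound 3 (beyond the scatter). The further extension, a number 7.1 percentage points higher from compound 2 to compound 3 (within the scatter), stays within the scatter. Compound 4 `CCCCC(=O)NCCC(=O)c1cc(OC)ccc1N` differs from compound 3 by methyl in place of hydrogen on a saturated chain carbon, three bonds along the chain from a carbonyl carbon. The bearing step is that from compound 2 to compound 3, a chain extension one bond further in, which gave no change beyond the scatter; the expectation is therefore a number 0.4 percentage points lower from compound 3 to compound 4 (within the scatter), no step beyond the scatter. Compound 4 is estimated at 7%, within 0% to 22%.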

Compound 4, a percentage reported as inhibition, at one concentration (the size of the read-out at that concentration, not a potency): 14.1%
Estimate against measurement, compound 4: 7.1 percentage points below; measured number inside the range.
By their numbers in this assay, from the lowest: compounds 2, 3 and 4 (each within the scatter of the next, the first and the last beyond it); then compound 1.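

In this assay the step at this position stays within the scatter, a number 6.8 percentage points higher from compound 3 to compound 4 (within the scatter), yet the two extensions together give a number 13.9 percentage points higher from compound 2 to compound 4 (beyond the scatter), a rise beyond the scatter that neither single step showed. The drop from the shortest acyl chain is only partly recovered, a number 16.6 percentage points lower from compound 1 to compound 4 (beyond the scatter). Adding carbons therefore does not read the same at each chain length: the same change on two cores in this assay, a number 23.4 percentage points lower (beyond the scatter) from compound 1 to compound 3 and a number 13.9 percentage points higher (beyond the scatter) from compound 2 to compound 4, 37.2 percentage points apart, beyond the scatter of two such steps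

As far as these compounds go, whether a longer chain continues this rise remains open. So does the effect of an amine or a carboxylic acid at the chain end.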